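A few compounds are considered here, and "the series" means these few. Any claim that something is new, unique, unknown or untested is made for them only; others in the source may bear on it.

In a functional assay on NCI-H460 cells (Homo sapiens) for antiproliferative activity, read by MTT assay, with a stated time of 48 h (a higher number here means a weaker inhibitor, a lower number a stronger inhibitor), compound 1 `COc1cc(-c2cccc3nc(-c4cccc(F)c4)oc23)cc(OC)c1OC` gives 3300 nM as a measured number. Compound 2 `COc1cc(-c2cccc3nc(-c4ccc(Cl)cc4)oc23)cc(OC)c1OC` gives > 25000 nM and this is a limit. Compound 3 `COc1ccc(-c2cccc3nc(-c4ccc5cc[nH]c5c4)oc23)c(OC)c1OC` gives > 25000 nM and this too is a limit. Compound 2 therefore stands at the limit of > 25000 nM in this assay, at which 2 of the 3 values shown sit, and has no number of its own.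

Compound 4 `COc1cc(-c2cccc3nc(-c4ccco4)oc23)cc(OC)c1OC` is still unmeasured and differs from compound 2 by furan-2-yl in place of 4-chlorophenyl on an aromatic carbon on the shared core. The furan-2-yl group takes the place of 4-chlorophenyl on the aromatic carbon next to the ring nitrogen and next to the ring oxygen.

Among the measured compounds shown here, one measured step bears on this place: an at least 7.5-fold higher number from compound 1 to compound 2 (0.87 log units; beyond the scatter) shows that the group there can matter. For the measured compounds named here, no measured compound carries furan-2-yl, so the size of the change is uncertain. Compound 1 at 3300 nM suggests that a lower number is possible without 4-chlorophenyl, so a modest move in that direction is expected. Another limit reading could still occur for compound 4. The expected size is an at least 2.7-fold lower number from compound 2 to compound 4 (0.44 log units; beyond the scatter) as an estimate only. For compound 4 the estimate is 9000 nM with 2000 nM to 30000 nM as the expected range.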

Compound 4, half-maximal inhibitory concentration: 2600 nM
Estimate against measurement, compound 4: 3.5-fold (0.54 log units) above, within the range that was stated.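

In this assay, a measurable value at this place does not depend on a phenyl ring: furan-2-yl in place of 4-chlorophenyl gives an at least 9.6-fold lower number from compound 2 to compound 4 (0.98 log units; beyond the scatter). Furan-2-yl in place of 3-fluorophenyl gives a 1.3-fold lower number from compound 1 to compound 4 (0.10 log units; within the scatter), so this assay does not separate these two groups, and the smaller five-membered aromatic ring serves here as well as the 3-fluorophenyl ring. Compound 2 has a limit and not a number: the limit of > 25000 nM in this assay, at which 2 of the 4 values shown sit.

Every group shown at this place is an aromatic ring, so the effect of an amine, a carboxylic acid or a longer alkyl chain there remains open. Also open, as far as these compounds go, is whether the chlorine or its place on the ring sets 4-chlorophenyl apart from 3-fluorophenyl, since the two groups differ in both.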